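Enantiomer pair in the HEp-2 cytotoxicity series

The source may hold more compounds than are shown below. What is called first, only, known or untested is meant among the compounds shown, and "the series" means these compounds.

Measured so far:
compound 1, `CC[C@@H](CCn1cncn1)c1ccc(Cl)cc1`: 55.1 ug/mL
compound 2, `CC[C@H](CCn1cncn1)c1ccc(OC)cc1`: 153 ug/mL

In an ADME assay on HEp-2 cells (Homo sapiens) for cytotoxicity, read by MTT assay, with a stated time of 3 days (a higher number here means that more compound is tolerated, a lower number that less compound is tolerated), compound 2 gives 153 ug/mL, the higher of the two numbers recorded. Going by the values given here, its nearest neighbour is compound 1, which in this assay gives 55.1 ug/mL; the gap between the two is beyond the usual scatter, though no single-point step links them, so the two values are simply reported side by side.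

The next compound, compound 3, `CC[C@@H](CCn1cncn1)c1ccc(OC)cc1`, is the mirror image of compound 2: the two compounds have the same atoms and bonds and differ only in configuration as drawn: 1 of 1 stereo elements differ; a stereocentre at a saturated chain carbon is drawn R in compound 2 and S in compound 3. Nothing leaves and nothing enters.

Among the compounds with values here, no step between measured compounds is available for a change of this kind. A pair differing only in configuration at one saturated chain carbon is expected to stay within the scatter in this assay, so the step of a 1.2-fold lower number from compound 2 to compound 3 (0.07 log units; within the scatter) is estimated to be small and of no firm direction. On that basis compound 3 is expected to give about 130 ug/mL in this assay, with a range from 60 ug/mL to 300 ug/mL.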

Compound 3, half-maximal cytotoxic concentration: 146 ug/mL
Beside the measured number, compound 3's estimate is 1.1-fold (0.05 log units) below it, and the stated range covers the measured number.
By their numbers in this assay, from the lowest: compound 1; then compounds 3 and 2 (each within the scatter of the next).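

In this assay, going by these compounds alone, the mirror-image pair gives the first direct reading at the saturated chain carbon: a 1.0-fold lower number from compound 2 to compound 3 (0.02 log units; within the scatter), so with methoxy on the aromatic carbon, the configuration drawn at this stereocentre leaves the number within the scatter. Within the data shown here, the second step separates the aromatic change from the stereocentre, which the earlier pair of compound 1 and compound 2 could not do because both features differed there: with methoxy in place of chloro on an aromatic carbon as the only change, the series shows a 2.6-fold higher number from compound 1 to compound 3 (0.42 log units; beyond the scatter), and this is the one new step beyond the scatter. The reading of the stereocentre rests on a comparison with no other structural variable: the fact that compounds 2 and 3 differ only in the configuration as drawn.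

Whether the configuration is equally without effect on the number with chloro on the aromatic carbon remains open, since only one configuration of that compound is shown. A single replacement also cannot show how the number would respond to other groups on that carbon, such as an amine or a carboxylic acid.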